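A few compounds are considered here, and "the series" means these few. Any claim that something is new, unique, unknown or untested is made for them only; others in the source may bear on it.

Going by the values given here, compound 1 `C=CCN(CCCC(=O)OCC)C(=O)/C(C)=C/c1ccc(C(=O)Oc2ccc(C(=N)N)cc2)cc1` is one of two compounds measured in an in vitro ADME assay on the whole organism (small intestine) for pharmacokinetics, with Rattus norvegicus as the target; a lower number here means that the compound disappears faster, a higher number that the compound lasts longer; in that test compound 1 gives 1 h. Compound 2 `CCOC(=O)CN(Cc1ccccc1)C(=O)/C(C)=C/c1ccc(C(=O)Oc2ccc(C(=N)N)cc2)cc1` gives 0.733 h in this assay, and the two numbers lie within the scatter of each other, so neither stands apart. Compound 3 `C=CCN(CCCC(=O)O)C(=O)/C(C)=C/c1ccc(C(=O)Oc2ccc(C(=N)N)cc2)cc1` has not yet been measured. Compared with compound 1 it carries hydrogen in place of ethyl on an oxygen next to a carbonyl group. Among the compounds with values here, no measured pair shows this change, so the expectation rests on the structure alone. Compound 3 is expected to last longer, by a step of a 2.5-fold higher number from compound 1 to compound 3 (0.40 log units; beyond the scatter) that goes beyond the scatter. The estimate for compound 3 in this assay is 2.5 h, with a range from 0.9 h to 7 h.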

Compound 3, half-life: 0.917 h
Compound 3: the middle estimate sits 2.7-fold (0.44 log units) above what was measured; measured number inside the range.
By their numbers in this assay, from the lowest: compounds 2, 3 and 1 (each within the scatter of the next).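

In this assay, going from ethoxycarbonyl to carboxy gives a 1.1-fold lower number from compound 1 to compound 3 (0.04 log units; within the scatter), so in this read-out the two compounds cannot be told apart. Going by these compounds alone, this is the first pair to differ only at this oxygen, which compound 2, differing from compound 1 in more than one place, could not show. Nothing measured here gives a reason for this result. As far as these compounds go, whether a longer chain such as butyl on this oxygen, or an amide in place of the ester, would fall equally close remains open. So does whether the same swap on compound 2 would give a similar step.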